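Pyrazolyl for Allyloxy: Expected Serum Binding of Compound 4

This account rests on a few compounds, and the source may have more. Where it says the series, first, only, none or still open, it means among the compounds named here.

Three aryl hydrazides sharing a fluorophenylsulfonyl hydrazide core have been run through an ADME assay on a cell-free system (serum, Bos taurus) for protein binding. Compound 1 `C=CCOc1cc(F)cc(C(=O)NNS(=O)(=O)c2ccccc2F)c1` gives 80.6%, and its two neighbours both fall within the usual scatter of that value: compound 2 `Cc1cc(C(=O)NNS(=O)(=O)c2ccccc2F)cc(-n2cc(F)cn2)c1` gives 83.2%, and compound 3 `CCOc1cc(C)cc(C(=O)NNS(=O)(=O)c2ccccc2F)c1` gives 73.6%. Among the measured compounds shown here, the one step between measured compounds, a 1.6-fold higher unbound fraction from compound 2 to compound 3 (0.20 log units; within the scatter), swaps ethoxy for 4-fluoro-1H-pyrazol-1-yl and stays inside the scatter.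

Compound 4 `O=C(NNS(=O)(=O)c1ccccc1F)c1cc(F)cc(-n2cccn2)c1` has not yet been measured. Relative to compound 1 it carries the change (1H-pyrazol-1-yl in place of allyloxy on an aromatic carbon). The step from compound 2 to compound 3 is the nearest guide, since it also exchanges an alkoxy group for a pyrazolyl ring on the same aromatic carbon, in the opposite direction; the pyrazolyl partner there, compound 2, shows 83.2%. On that basis only a small shift toward more binding is expected, not beyond the scatter: a 1.2-fold lower unbound fraction from compound 1 to compound 4 (0.08 log units; within the scatter). Compound 4 is therefore estimated at 84%, with a range from 72% to 92% in this assay.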

Compound 4, plasma protein binding: 67.2%
For compound 4 the middle estimate is 2.1-fold (0.31 log units) (unbound fraction) below the measured one, outside the stated range (below it).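

In this assay, among the compounds shown here, the step with the fluoro group kept in place, a 1.7-fold higher unbound fraction from compound 1 to compound 4 (0.23 log units; within the scatter), is the first direct exchange of allyloxy for 1H-pyrazol-1-yl on this aromatic carbon. It shows that an open chain with a double bond can give way to a five-membered aromatic ring with two hetero atoms at this position, meta to the fluoro group, without the read-out leaving the scatter. Nothing measured here explains the result.

The compounds shown leave open whether an amine or a carboxylic acid on this aromatic carbon would move the read-out in this assay beyond the scatter. They also leave open whether a longer alkoxy chain would stay within it.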